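This account rests on a few compounds, and the source may have more. Where it says the series, first, only, none or still open, it means among the compounds named here.

Measured compounds in an assay on HEK293 cells for displacement of a labelled ligand from D(3) dopamine receptor (Rattus norvegicus), with a stated time of 1 h; a lower number here means a stronger inhibitor, a higher number a weaker inhibitor:
compound 1, `CCCN(CCC/C=C/c1ccc(O)c(OC)c1)[C@H]1CCc2nc(N)sc2C1`: 22.3 nM
compound 2, `CCCN(CCCCCc1ccc(O)c(OC)c1)C1CCc2nc(N)sc2C1`: 3.62 nM
compound 3, `CCCN(CCCCCc1ccc(O)c(OC)c1)[C@H]1CCc2nc(N)sc2C1`: 1.57 nM

Compound 2 gives the second highest number of the three: its nearest neighbour is compound 3, and the step of a 2.3-fold lower number from compound 2 to compound 3 (0.36 log units; beyond the scatter) separates them. Compound 1, with the unsaturated chain, lies furthest away. Among the measured compounds shown here, the only step that can be read as a single change is a 2.3-fold lower number from compound 2 to compound 3 (0.36 log units; beyond the scatter); it turns on (the fact that one of compounds 2 and 3 is drawn with a defined configuration and the other without, at the place where they differ), not on the aromatic ring, and so says nothing about a swap on the aryl end.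

Compound 4, `CCCN(CCCCCc1cc(O)ccc1O)C1CCc2nc(N)sc2C1`, differs from compound 2 by 2,5-dihydroxyphenyl in place of 4-hydroxy-3-methoxyphenyl on a saturated chain carbon, five bonds along the chain from an amine nitrogen. For the measured compounds named here, no pair among the measured compounds changes the aromatic substitution, so there is no measured step that bears on this change, and no direction can be drawn from the data. The measured range of the series is narrow, and the shared core, the propyl group and the five-carbon chain are unchanged.

For this assay a modest loss is taken as the working expectation, with wide uncertainty: the step of a 2.2-fold higher number from compound 2 to compound 4 (0.34 log units; beyond the scatter) is the estimated change. Compound 4 is expected to give 8 nM, with a range from 2 nM to 40 nM.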

Compound 4, inhibition constant: 1.01 nM
Compound 4: middle estimate off by 7.9-fold (0.90 log units), on the high side; measured number below the stated range.
By their numbers in this assay, from the lowest: compounds 4 and 3 (each within the scatter of the next); then compound 2; then compound 1.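

In this assay, among the compounds shown here, 2,5-dihydroxyphenyl in place of 4-hydroxy-3-methoxyphenyl gives a 3.6-fold lower number from compound 2 to compound 4 (0.55 log units; beyond the scatter), the first measured step that bears on the aromatic substitution at this place, on a saturated chain carbon, five bonds along the chain from an amine nitrogen. The step shows that the number responds to the aromatic substitution, and that the 4-hydroxy-3-methoxyphenyl group of compound 2 is not required for a low number, as the 2,5-dihydroxyphenyl group gives a lower one with the shared core, the propyl group and the five-carbon chain unchanged. No evidence at hand bears on why this swap moves the number.

The swap alters the methoxy group and the hydroxyl pattern together, so the share of each in the step stays unresolved, and 3,4-dihydroxyphenyl, 2,5-dimethoxyphenyl or plain phenyl in the same place would be needed to separate them. Going by these compounds, it also remains open whether the step carries over to the unsaturated chain of compound 1 or to the defined configuration of compound 3.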